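Cytotoxicity notes on the shared-core series, compound 2 to 3

A few compounds are considered here, and "the series" means these few. Any claim that something is new, unique, unknown or untested is made for them only; others in the source may bear on it.

Compound 1 `CCCCCCCCOc1nc(N)nc2c1ncn2/C=C1/CC1(CO)CO` was tested in an ADME assay on Akata cells (Homo sapiens) for cytotoxicity, with a stated time of 7 days (a higher number here means that more compound is tolerated, a lower number that less compound is tolerated), and gives > 20000 nM, which is a limit of the assay rather than a number. Compound 2 `CSc1nc(N)nc2c1ncn2/C=C1/CC1(CO)CO` likewise gives > 20000 nM in this assay, again a limit. The step from compound 1 to compound 2 in this assay is a step that the two limits leave unreadable from compound 1 to compound 2, so its size cannot be read. Both values shown sit at the same place: the limit of > 20000 nM in this assay, at which 2 of the 2 values shown sit. Compound 2 therefore stands only at a limit on the numbers shown, with no readable position against compound 1.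

Compound 3 `CCCCNc1nc(N)nc2c1ncn2/C=C1/CC1(CO)CO` differs from compound 2 by butylamino in place of methylsulfanyl on an aromatic carbon. Among the compounds with values here, the only measured step that touches this position, a step that the two limits leave unreadable from compound 1 to compound 2, gives no readable size, so there is nothing that points to a step in either direction in this assay beyond the scatter. The expectation for compound 3 is that it also sits at the limit, a step of a number no higher from compound 2 to compound 3 (the limit leaves the size open) from compound 2. For compound 3 the estimate in this assay is 20000 nM, within a range from 8000 nM to 50000 nM.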

Compound 3, half-maximal cytotoxic concentration: > 24000 nM
Compound 3 was reported as a limit (the forecaster's own chance of this, stated with the estimate: 80%); middle value at least 1.2-fold (0.07 log units) from the limit.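

In this assay compound 3 gives > 24000 nM, which is a limit of the assay and not a number. Within the data shown here, no step among compound 1, compound 2 and compound 3 can be read, since all three values are limits. The compounds shown leave open whether octyloxy, methylsulfanyl and butylamino differ at all in this assay.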